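This account rests on a few compounds, and the source may have more. Where it says the series, first, only, none or still open, it means among the compounds named here.

Measured in a functional assay with Oryctolagus cuniculus as the target; a lower number here means a stronger inhibitor, a higher number a weaker inhibitor:
Compound 1 `COc1ccc(-c2nc(/N=C(\N)NC(C)C)sc2-c2ccc(OC)cc2)cc1`: > 100 nM
Compound 2 `COc1ccc(-c2nc(/N=C(\N)[N+]3(C)CCCCC3)sc2-c2ccc(OC)cc2)cc1`: > 1000 nM
Compound 3 `COc1ccc(-c2nc(CNC(=O)NC(C)C)sc2-c2ccc(OC)cc2)cc1`: 42 nM

The entry for compound 1 is a limit. The entry for compound 2 is also a limit. Going by the values given here, compound 3 therefore holds the only true number, and it is the strongest inhibitor of the three.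

The next compound is compound 4 `COc1ccc(-c2nc(C(=O)N3CCCCC3)sc2-c2ccc(OC)cc2)cc1`, and the change is (piperidin-1-yl)carbonyl in place of ((isopropylcarbamoyl)amino)methyl on an aromatic carbon. Among the compounds with values here, no measured compound carries this group at that place. Within the data shown here, two steps bear on the same aromatic carbon, an at least 2.3-fold lower number from compound 1 to compound 3 (0.37 log units; beyond the scatter) and an at least 23-fold lower number from compound 2 to compound 3 (1.37 log units; beyond the scatter), and both favour the group that compound 4 gives up. A moderate loss is therefore expected in this assay, with an expected step of a 2.4-fold higher number from compound 3 to compound 4 (0.38 log units; beyond the scatter). For compound 4 the estimate is 100 nM, within an expected range of 25 nM to 400 nM.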

Compound 4, half-maximal inhibitory concentration: > 1000 nM
Compound 4: a limit, no number; the forecaster's own chance of this, stated with the estimate: 25%; at least 10-fold (1.00 log units) between middle value and limit.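

In this assay, (piperidin-1-yl)carbonyl in place of ((isopropylcarbamoyl)amino)methyl on this aromatic carbon gives an at least 23-fold higher number from compound 3 to compound 4 (1.37 log units; beyond the scatter), so this position does not accept every neutral group of 8 heavy atoms. The two groups match in heavy atoms but differ in the ring and in hydrogen-bond donors, 0 against 2. The entry for compound 4 is a limit: the limit of > 1000 nM in this assay, at which 2 of the 4 values shown sit.

The steps linking compound 4 to compound 1 and compound 2 cannot be read. An open-chain isopropyl amide at this carbon could show whether the ring or the missing donors matter more.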